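Benzyloxy substituent variation in a phenoxyethylamine series

The compounds below may be only part of what the source reports. "The series", "measured", "known", "first", "only" and "open" are said of these compounds alone.

Measured compounds:
compound 1 `COc1cccc(OC)c1OCCNCCOc1ccccc1OCc1ccccc1`, 9.37
compound 2 `COc1cccc(OC)c1OCCNCCOc1ccccc1OCc1cccc(C)c1`, 8.85
compound 3 `COc1cccc(OC)c1OCCNCCOc1ccccc1OCc1cccc([N+](=O)[O-])c1`, 9.28

In a functional assay on thoracic aorta for antagonist activity at Alpha-1D adrenergic receptor (Rattus norvegicus) (a lower number here means a less potent compound, a higher number a more potent compound, by a factor of ten per unit of this negative logarithm), compound 3 stands second of the three: compound 1 lies within the scatter of it, while compound 2 sits lower (a number 0.43 log units higher from compound 2 to compound 3 (beyond the scatter)). Compound 4 `COc1ccccc1COc1ccccc1OCCNCCOc1c(OC)cccc1OC` carries 2-methoxyphenyl in place of 3-nitrophenyl on a saturated chain carbon bound to an oxygen on an aromatic ring. Within the data shown here, no measured step exchanges a nitro for a methoxy group, and none places a substituent as 2-methoxyphenyl does, so the bearing of the change is indirect. The steps at hand are a number 0.09 log units lower from compound 1 to compound 3 (within the scatter) and a number 0.52 log units lower from compound 1 to compound 2 (beyond the scatter): substitution on the benzyl ring has so far cost nothing or a modest amount in this assay. The step of a number 0.18 log units lower from compound 3 to compound 4 (within the scatter) is therefore expected to be small, with a slight lean downward. Compound 4 is estimated at 9.1, with a range of 8.5 to 9.6.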

Compound 4, negative logarithm of the antagonist equilibrium constant: 8.86
Compound 4: the middle estimate sits 0.24 log units above what was measured; low and high end bracket the measured number.
By their numbers in this assay, from the lowest: compounds 2 and 4 (each within the scatter of the next); then compounds 3 and 1 (each within the scatter of the next).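

Compound 4 shows in this assay that the benzyl ring does not tolerate every substituent equally: (a number 0.51 log units lower from compound 1 to compound 4 (beyond the scatter)) and (a number 0.42 log units lower from compound 3 to compound 4 (beyond the scatter)). Against the 3-methylphenyl group the step is negligible (a number 0.01 log units higher from compound 2 to compound 4 (within the scatter)), so 2-methoxyphenyl and 3-methylphenyl cannot be told apart here, and among the three substituted groups only 3-nitrophenyl stays within the scatter of compound 1. Nothing available explains these steps.

Open, on these data alone, is how an amine or a carboxylic acid on the benzyl ring would read in this assay, and whether any group other than 3-nitrophenyl also keeps the level of compound 1.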